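A few compounds are considered here, and "the series" means these few. Any claim that something is new, unique, unknown or untested is made for them only; others in the source may bear on it.

Measured compounds:
Compound 1 `O=C(CN1CCN(c2ccccc2)CC1)N1CCN(c2nnc(-c3ccccc3)c(-c3ccccc3)n2)CC1` gives, in an ADME assay on NIH3T3 cells (Mus musculus) for cytotoxicity, read by MTT assay, with a stated time of 24 h (on this read-out lower numbers stand for stronger inhibition and higher numbers for weaker inhibition), a limit of > 963000 nM.
Compound 2 `COc1ccc(-c2nnc(N3CCN(C(=O)CN4CCN(c5ccccc5)CC4)CC3)nc2-c2ccc(OC)cc2)cc1` gives, in this assay, a limit of > 863000 nM.

Both results here are limits of the assay rather than numbers, so compound 2 cannot be ranked against compound 1; each simply sits at its own limit. Compound 3 `COc1ccc(-c2nnc(N3CCN(C(=O)CN4CCN(c5ccc(Cl)cc5)CC4)CC3)nc2-c2ccc(OC)cc2)cc1` differs from compound 2 by chloro in place of hydrogen on an aromatic carbon. Among the measured compounds shown here, with no measured step to draw on, no shift beyond the scatter is expected in this assay, and the outcome will most probably again be a limit. The expected change is a step that the limit leaves unreadable from compound 2 to compound 3. Compound 3 is estimated at 900000 nM, with a range from 300000 nM to 1000000 nM.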

Compound 3, half-maximal inhibitory concentration: > 814000 nM
Compound 3: only a limit was reported (the forecaster's own chance of this, stated with the estimate: 85%); the middle value does not contradict the limit.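

In this assay compound 3 gives only a limit, > 814000 nM. Compound 2 is also a limit, so no step can be read between compound 2 and compound 3. The compounds shown leave open whether phenyl to 4-chlorophenyl shifts the value at all.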